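Working notes: from compound 3 to compound 4

The source may hold more compounds than are shown below. What is called first, only, known or untested is meant among the compounds shown, and "the series" means these compounds.

The three measured compounds share one core and differ only in the aryl group on a saturated chain carbon bound to an amine nitrogen. Compound 1 `CC(C)(C)c1ccc(CNCCCNS(=O)(=O)c2cc(C(F)(F)F)cc(C(F)(F)F)c2)cc1` gives 2300 nM in a functional assay on MIA PaCa-2 cells (Homo sapiens) for inhibition, read by MTT assay, with a stated time of 72 h; a lower number here means a stronger inhibitor of growth, a higher number a weaker inhibitor of growth. Compound 2 `O=S(=O)(NCCCNCc1cccc(Cl)c1)c1cc(C(F)(F)F)cc(C(F)(F)F)c1` gives 4400 nM, and compound 3 `O=S(=O)(NCCCNCc1ccc(C(F)(F)F)cc1)c1cc(C(F)(F)F)cc(C(F)(F)F)c1` gives 2500 nM. Compound 3 stands second highest of the three numbers, nearest to compound 1 and furthest from compound 2, with both gaps inside the scatter. The measured steps were a 1.9-fold higher number from compound 1 to compound 2 (0.28 log units; within the scatter), a 1.1-fold higher number from compound 1 to compound 3 (0.04 log units; within the scatter) and a 1.8-fold lower number from compound 2 to compound 3 (0.25 log units; within the scatter); none of them reaches beyond the scatter, so the three aryl groups tried so far are indistinguishable on these numbers.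

Compound 4 `O=S(=O)(NCCCNCc1ccc(Cl)c(C(F)(F)F)c1)c1cc(C(F)(F)F)cc(C(F)(F)F)c1` has no value yet in this assay. It differs from compound 3 in one place: 4-chloro-3-(trifluoromethyl)phenyl in place of 4-(trifluoromethyl)phenyl on a saturated chain carbon bound to an amine nitrogen. All three measured steps bear on this change, since each also swaps the aryl group at the same place, and each stayed within the scatter. The expectation for compound 4 is therefore a step of no change at the digits printed from compound 3 to compound 4 (within the scatter) in this assay, that is, nothing beyond the scatter. Compound 4 is estimated at 2500 nM, with an expected range from 1100 nM to 5600 nM.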

Compound 4, concentration for 50% growth inhibition: 7400 nM
The estimate for compound 4 lay 3.0-fold (0.47 log units) below the measured number; measured number above the stated range.
By their numbers in this assay, from the lowest: compounds 1, 3, 2 and 4 (each within the scatter of the next, the first and the last beyond it).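

The aryl group on a saturated chain carbon bound to an amine nitrogen now produces steps beyond the scatter in this assay: 4-chloro-3-(trifluoromethyl)phenyl gives a 3.0-fold higher number from compound 3 to compound 4 (0.47 log units; beyond the scatter) against 4-(trifluoromethyl)phenyl and a 3.2-fold higher number from compound 1 to compound 4 (0.51 log units; beyond the scatter) against 4-(tert-butyl)phenyl, so this place is not indifferent to the choice of aryl group. The same group gives a 1.7-fold higher number from compound 2 to compound 4 (0.23 log units; within the scatter) against 3-chlorophenyl, so compound 2 and compound 4 cannot be told apart and the series does not separate into a clean order at this place. No measurement at hand accounts for these steps.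

Compared with compound 3, compound 4 carries an added chlorine and a different placement of trifluoromethyl, so the step cannot be assigned to either feature alone, and a phenyl carrying only the chloro or only the trifluoromethyl of 4-chloro-3-(trifluoromethyl)phenyl would be needed to separate them. Going by these compounds, whether the step persists with a longer chain in the shared core, or with an amide in place of the amine, also remains open.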